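The source may hold more compounds than are shown below. What is called first, only, known or untested is meant among the compounds shown, and "the series" means these compounds.

Measured compounds:
Compound 1, `Cc1cc(/C=C/C#N)cc(C)c1Oc1cc(Nc2ccc(C#N)cc2)c(N)cc1C(N)=O`. In an ADME assay on TZM cells (Homo sapiens) for cytotoxicity, read by XTT assay, with a stated time of 4 days (on this read-out higher numbers stand for lower toxicity in this test and lower numbers for higher toxicity in this test), compound 1 gives > 23600 nM, which is a limit of the assay and not a number.
Compound 2, `Cc1cc(/C=C/C#N)cc(C)c1Oc1cc(Nc2ccc(C#N)cc2)c(N)cc1S(N)(=O)=O`. In this assay compound 2 gives > 21800 nM, again a limit of the assay.
Compound 3, `Cc1cc(CCC#N)cc(C)c1Oc1cc(Nc2ccc(C#N)cc2)c(N)cc1C(N)=O`. In this assay compound 3 gives > 9400 nM, also a limit of the assay.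

Compound 4, `Cc1cc(CCC#N)cc(C)c1Oc1cc(Nc2ccc(C#N)cc2)c(N)cc1S(N)(=O)=O`, has not yet been measured in this assay. Compound 2 differs from compound 1 in one place: sulfamoyl in place of carbamoyl on an aromatic carbon. The measured step for this pair is a step that the two limits leave unreadable from compound 1 to compound 2. Compound 3 differs from compound 1 in another place: 2-cyanoethyl in place of 2-cyanoethenyl on an aromatic carbon. Here the step is a step that the two limits leave unreadable from compound 1 to compound 3. Compound 4 differs from compound 3 by sulfamoyl in place of carbamoyl on an aromatic carbon, the same change as from compound 1 to compound 2, at a place described in the same words. All three values shown are limits: the limit of > 23600 nM in this assay, at which 1 of the 3 values shown sits, the limit of > 21800 nM in this assay, at which 1 of the 3 values shown sits, and (the limit of > 9400 nM in this assay, at which 1 of the 3 values shown sits). With every value at a limit, the first step gives no size to carry over. Compound 4 is therefore expected to sit at or near the limit as well, and the step that the limit leaves unreadable from compound 3 to compound 4 is estimated to be small. Compound 4 is expected to give 22000 nM in this assay, estimated between 9000 nM and 80000 nM.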

Compound 4, half-maximal cytotoxic concentration: 11100 nM
Estimate against measurement, compound 4: 2.0-fold (0.30 log units) above; the measured number falls inside the stated range.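

In this assay compound 4 gives 11100 nM. The sulfamoyl-for-carbamoyl change still cannot be sized on either core, and the other steps that end in a limit cannot be read either. Going by these compounds alone, the one step that can be read is an at least 1.9-fold lower number from compound 2 to compound 4 (0.29 log units; that floor lies within the scatter); it belongs to 2-cyanoethyl in place of 2-cyanoethenyl, not to the sulfamoyl change, and so says nothing directly about that change. The series therefore shows that the sulfamoyl group can be placed on both cores with a value recorded in this assay each time, but not that the change keeps its size from one core to the other, as compound 3 stands only at a limit: the limit of > 9400 nM in this assay, at which 1 of the 4 values shown sits.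

The compounds shown leave open how a carboxylic acid or a methylsulfonyl group would read at the place of the carbamoyl. They also leave open what a longer chain carrying the nitrile would give in place of 2-cyanoethyl.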